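A few compounds are considered here, and "the series" means these few. Any claim that something is new, unique, unknown or untested is made for them only; others in the source may bear on it.

Compound 1 `CC(C)N(Cc1cccc(OCCCCCC(=O)O)c1)C(=O)c1ccc(-c2cccc(-c3ccccc3)c2)cc1`. In an ADME assay on HEK293 cells (Homo sapiens) for cytotoxicity, read by CellTiter-Glo and resazurin assay, with a stated time of 72 h (a lower number here means that less compound is needed, a higher number that more compound is needed for the effect), compound 1 gives > 26000 nM, which is a limit of the assay rather than a number.
Compound 2 `CC(=O)c1cccc(-c2ccc(C(=O)N(Cc3cccc(OCCCCCC(=O)O)c3)C(C)C)cc2)c1`. In this assay compound 2 gives > 26000 nM, again a limit.
Compound 3 `CCOC(=O)CCCCCOc1cccc(CN(C(=O)c2ccc(-c3cccc(C(C)=O)c3)cc2)C(C)C)c1`. In this assay compound 3 gives > 26000 nM, also a limit.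

Compound 3 therefore stands at the edge of what the assay can report, and it shares that position with the other two compounds, since (the limit of > 26000 nM in this assay, at which 3 of the 3 values shown sit). The two measured steps, a step that the two limits leave unreadable from compound 1 to compound 2 and a step that the two limits leave unreadable from compound 2 to compound 3, run between limits and their size cannot be read. Compound 4 `CCOC(=O)CCCCCOc1cccc(CN(C(=O)c2ccc(-c3cccc(O)c3)cc2)C(C)C)c1` differs from compound 3 by hydroxy in place of acetyl on an aromatic carbon. The step from compound 1 to compound 2, which also changed the group on an aromatic carbon at this position, is the closest measured comparison, but it gives no readable size. With every measured value at the limit, no step beyond the scatter is expected, so compound 4 is expected to show a step that the limit leaves unreadable from compound 3 to compound 4. Compound 4 is estimated at 40000 nM, in a range from 15000 nM to 150000 nM, most likely reported again as a limit.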

Compound 4, half-maximal effective concentration: > 26000 nM
Compound 4 gave a limit, no number; the forecaster's own chance of this, stated with the estimate: 85%; the middle value is on the limit's open side.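

Compound 4 also gives a limit rather than a number in this assay, so no size can be read for its difference from compound 3: the limit of > 26000 nM in this assay, at which 4 of the 4 values shown sit.
The compounds shown leave open how much of any of them is needed for the effect, and whether hydroxy in place of acetyl changes that amount at all.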